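The compounds below may be only part of what the source reports. "The series", "measured", "known", "first", "only" and "open" are said of these compounds alone.

In a functional assay on MDA-MB-231 cells (Homo sapiens) for antiproliferative activity, read by MTT assay, with a stated time of 24 h (on this read-out lower numbers stand for stronger inhibition and higher numbers for weaker inhibition), two compounds sharing one core have been measured so far. Compound 1 `CCCCc1oc2ccccc2c1C(=O)c1ccc(OCC(=O)Nc2ccccc2)cc1` reaches only a limit of the assay, > 50000 nM. Within the data shown here, compound 2 `CCCCc1oc2ccccc2c1C(=O)c1ccc(OCC(=O)N[C@H](C)c2ccccc2)cc1` gives 39000 nM, the only actual number available, so it has no measured neighbour to be ranked against. Among the measured compounds shown here, the one measured step is an at least 1.2-fold lower number from compound 1 to compound 2 (0.10 log units; that floor lies within the scatter), with 1-phenylethyl in place of phenyl on an amide-type nitrogen.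

Compound 3 `CCCCc1oc2ccccc2c1C(=O)c1ccc(OCCCC(=O)N2CCOCC2)cc1` differs from compound 2 as follows: 2-((morpholin-4-yl)carbonyl)ethyl in place of (1-phenylethyl)carbamoyl on a saturated chain carbon bound to an oxygen on an aromatic ring. In short, 2-((morpholin-4-yl)carbonyl)ethyl stands in place of (1-phenylethyl)carbamoyl on a saturated chain carbon bound to an oxygen on an aromatic ring.

For the measured compounds named here, only the step of an at least 1.2-fold lower number from compound 1 to compound 2 (0.10 log units; that floor lies within the scatter) bears on this change, and it touches the same side of the molecule while replacing far less of it. It therefore offers no ground for expecting a large move in this assay, in either direction. The expected step is a 1.1-fold higher number from compound 2 to compound 3 (0.03 log units; within the scatter), which means no change beyond the scatter, and a report of only a limit would be no surprise. For compound 3 the estimated value is 42000 nM, with an expected range of 18000 nM to 95000 nM.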

Compound 3, half-maximal inhibitory concentration: 31600 nM
Estimate against measurement, compound 3: 1.3-fold (0.12 log units) above; measured number inside the range.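

In this assay, the exchange of the whole (1-phenylethyl)carbamoyl for 2-((morpholin-4-yl)carbonyl)ethyl, on a saturated chain carbon bound to an oxygen on an aromatic ring, amounts to a 1.2-fold lower number from compound 2 to compound 3 (0.09 log units; within the scatter). This is a much larger replacement than the earlier one: the six-membered aromatic ring of carbon only, the defined stereocentre and the hydrogen-bond donor all leave, and a six-membered non-aromatic ring with 2 hetero atoms enters, yet the number does not move beyond the scatter. The other new step, an at least 1.5-fold lower number from compound 1 to compound 3 (0.19 log units; that floor lies within the scatter), can be read only as a floor, since compound 1 stands at a limit of the assay and not at a number: the limit of > 50000 nM in this assay, at which 1 of the 3 values shown sits.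

The change from compound 2 to compound 3 alters the chain and the amide together, so the compounds shown do not separate the contribution of each. Going by these compounds, it also remains open whether another group at this place, such as a free carboxylic acid, a piperidine amide or a longer chain ending in an amine, would move the number beyond the scatter.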